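Thiophenyl position swap in a hydroxyphenyl series: working notes

The compounds below may be only part of what the source reports. "The series", "measured", "known", "first", "only" and "open" are said of these compounds alone.

Compound 1 `Oc1cccc(-c2cc(-c3ccccc3)cc(-c3cccs3)n2)c1` gives 18900 nM in a functional assay on DU-145 cells (Homo sapiens) for cytotoxicity, read by ELISA, with a stated time of 2 days; on this read-out higher numbers stand for weaker inhibition and lower numbers for stronger inhibition. Compound 2 `Oc1cccc(-c2cc(-c3ccccc3)cc(-c3ccsc3)n2)c1` differs from compound 1 by thiophen-3-yl in place of thiophen-2-yl on an aromatic carbon and in this assay compound 2 gives 11700 nM, a step of a 1.6-fold lower number from compound 1 to compound 2 (0.21 log units; within the scatter). Compound 3 `Oc1ccc(-c2cc(-c3ccccc3)cc(-c3cccs3)n2)cc1` differs from compound 1 by 4-hydroxyphenyl in place of 3-hydroxyphenyl on an aromatic carbon; in this assay compound 3 gives 3700 nM, a step of a 5.1-fold lower number from compound 1 to compound 3 (0.71 log units; beyond the scatter), and it stands lowest of the three measured numbers. Compound 4 `Oc1ccc(-c2cc(-c3ccccc3)cc(-c3ccsc3)n2)cc1` is not yet measured; it differs from compound 3 by thiophen-3-yl in place of thiophen-2-yl on an aromatic carbon. This is the same kind of change as that from compound 1 to compound 2, not the same: the aromatic carbon is here meta to a 4-hydroxyphenyl group rather than meta to a 3-hydroxyphenyl group. Beside a 1.6-fold lower number from compound 1 to compound 2 (0.21 log units; within the scatter), the step from compound 3 to compound 4 is expected to be a 1.5-fold lower number from compound 3 to compound 4 (0.17 log units; within the scatter), resting on that single earlier case, itself within the scatter. Compound 4 is estimated at 2500 nM in this assay, between 1000 nM and 6500 nM.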

Compound 4, half-maximal inhibitory concentration: 8500 nM
Compound 4: the middle estimate sits 3.4-fold (0.53 log units) below what was measured; measured number above the stated range.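

In this assay, thiophen-3-yl in place of thiophen-2-yl on the core of compound 3 gives a 2.3-fold higher number from compound 3 to compound 4 (0.36 log units; beyond the scatter), so the step seen on the core of compound 1 does not carry over: the same change on two cores in this assay, a 1.6-fold lower number (0.21 log units; within the scatter) from compound 1 to compound 2 and a 2.3-fold higher number (0.36 log units; beyond the scatter) from compound 3 to compound 4, 3.7-fold (0.57 log units) apart, beyond the scatter of two such steps. 4-Hydroxyphenyl in place of 3-hydroxyphenyl gives a 1.4-fold lower number from compound 2 to compound 4 (0.14 log units; within the scatter) on the thiophen-3-yl core, so the step seen on the thiophen-2-yl core does not carry over either: the same change on two cores in this assay, a 5.1-fold lower number (0.71 log units; beyond the scatter) from compound 1 to compound 3 and a 1.4-fold lower number (0.14 log units; within the scatter) from compound 2 to compound 4, 3.7-fold (0.57 log units) apart, beyond the scatter of two such steps. These four compounds show that each step depends on the other group, but they do not show why, or whether this extends to other cores in the series.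

Open, on these data alone, is whether an amine or a methoxy group in place of the hydroxyl, or a furan ring in place of the thiophene, would show the same dependence.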